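The source may hold more compounds than are shown below. What is called first, only, known or untested is meant among the compounds shown, and "the series" means these compounds.

Measured in a functional assay on DU-145 cells (Homo sapiens) for inhibition, read by trypan blue exclusion, with a stated time of 96 h; a lower number here means a stronger inhibitor of growth, a higher number a weaker inhibitor of growth:
- compound 1 `Cc1ccc(CS/C(=C/c2ccc(O)cc2)C(=O)c2ccc(Cl)cc2)cc1`: 10000 nM
- compound 2 `COc1ccccc1/C=C(/SCc1ccc(C)cc1)C(=O)c1ccc(Cl)cc1`: 10000 nM
- compound 3 `Cc1ccc(CS/C(=C/c2cc(Cl)cc(Cl)c2)C(=O)c2ccc(Cl)cc2)cc1`: 10000 nM

The three compounds share a core and differ only in one aryl group, and all three give the same value. Compound 3 therefore has no edge over the other two and no deficit against them.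

Compound 4 `Cc1ccc(CS/C(=C/c2cccc(Cl)c2Cl)C(=O)c2ccc(Cl)cc2)cc1` has not yet been measured. It has the same atoms as compound 3, joined differently: 2,3-dichlorophenyl in place of 3,5-dichlorophenyl on a double-bonded chain carbon bound to a double-bonded chain carbon. In words, 2,3-dichlorophenyl replaces 3,5-dichlorophenyl on a double-bonded chain carbon bound to a double-bonded chain carbon.

All three measured steps changed the group at this same place, so all of them bear on the question. They read no change at the digits printed from compound 1 to compound 2 (within the scatter), no change at the digits printed from compound 1 to compound 3 (within the scatter) and no change at the digits printed from compound 2 to compound 3 (within the scatter). None of the three compounds goes against this flat picture, though none of them carries the 2,3-dichlorophenyl group, so a surprise cannot be ruled out. No shift beyond the scatter is therefore expected in this assay, in either direction.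

The expected step is no change at the digits printed from compound 3 to compound 4 (within the scatter).

For compound 4 the estimated value is 10000 nM, with an expected range from 5000 nM to 20000 nM.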

Compound 4, concentration for 50% growth inhibition: 25000 nM
Estimate against measurement, compound 4: 2.5-fold (0.40 log units) below; measured number outside the range, above it.
By their numbers in this assay, from the lowest: compounds 1, 2 and 3 (each within the scatter of the next); then compound 4.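

In this assay, this place on the double-bonded chain carbon is no longer flat: moving the two chlorines around the ring, with the same atoms in the group, gives a 2.5-fold higher number from compound 3 to compound 4 (0.40 log units; beyond the scatter), a modest weakening of growth inhibition. So the arrangement of the chlorines can shift the result, even though the earlier swaps of whole aryl groups showed nothing beyond the scatter. The 2,3-dichlorophenyl group also stands apart from the other two groups, with a 2.5-fold higher number from compound 2 to compound 4 (0.40 log units; beyond the scatter) and a 2.5-fold higher number from compound 1 to compound 4 (0.40 log units; beyond the scatter), which makes compound 4 the weakest of the four, though nothing measured here explains the shift.

On these data alone, what remains open is whether any group at this place can move the number the other way, toward stronger inhibition, for instance an aryl ring carrying an amine or a carboxylic acid. As far as these compounds go, it is also open whether changes elsewhere on the shared core, such as a longer chain in place of the methyl group, would shift the value at all.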